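The source may report more compounds than this note shows. Statements on the series, on what has been measured and on what is new or still open speak of the compounds shown alone.

Three compounds share one core and differ only in the aryl group on the triazole nitrogen. Compound 1 `CC1(C)[C@H]2CC[C@]1(C)N(Cc1cn(-c3ccc(C#N)cc3)nn1)C(=O)C2` gives 90 nM in a functional assay on LoVo cells (Homo sapiens) for inhibition, read by MTT assay, with a stated time of 24 h (a higher number here means a weaker inhibitor, a lower number a stronger inhibitor), compound 2 `CC1(C)[C@H]2CC[C@]1(C)N(Cc1cn(-c3cccc(C#N)c3)nn1)C(=O)C2` gives 320 nM, and compound 3 `CC1(C)[C@H]2CC[C@]1(C)N(Cc1cn(-c3ccc(F)cc3)nn1)C(=O)C2` gives 40 nM. Compound 3 stands lowest of the three: the step of a 2.3-fold lower number from compound 1 to compound 3 (0.35 log units; beyond the scatter) and the step of an 8.0-fold lower number from compound 2 to compound 3 (0.90 log units; beyond the scatter) both lie beyond the scatter, while the step of a 3.6-fold higher number from compound 1 to compound 2 (0.55 log units; beyond the scatter) shows that moving the nitrile around the ring also matters.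

Compound 4 `CC1(C)[C@H]2CC[C@]1(C)N(Cc1cn(-c3ccc(Br)cc3)nn1)C(=O)C2` has not yet been measured. It differs from compound 3 in one place: bromo in place of fluoro on an aromatic carbon. For the measured compounds named here, no measured step exchanges one halogen for another; the only step touching this position, a 2.3-fold lower number from compound 1 to compound 3 (0.35 log units; beyond the scatter), was modest, and the halogen-to-halogen change is smaller in kind than a nitrile-to-fluoro change. Compound 4 is therefore expected to sit close to compound 3, with the step of a 1.3-fold higher number from compound 3 to compound 4 (0.10 log units; within the scatter) most likely within the scatter. The estimate for compound 4 is 50 nM, with a range from 20 nM to 130 nM.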

Compound 4, half-maximal inhibitory concentration: 60 nM
The estimate for compound 4 lay 1.2-fold (0.08 log units) below the measured number, and the stated range covers the measured number.
By their numbers in this assay, from the lowest: compounds 3, 4 and 1 (each within the scatter of the next, the first and the last beyond it); then compound 2.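

In this assay, for the compounds shown here, the first exchange of one halogen for another at this position stays within the scatter (a 1.5-fold higher number from compound 3 to compound 4 (0.18 log units; within the scatter)), so fluoro and bromo, para to a large group, cannot be told apart here. Bromo also cannot be told apart from the nitrile of compound 1 (a 1.5-fold lower number from compound 1 to compound 4 (0.18 log units; within the scatter)), although fluoro could be, which leaves the three para groups less clearly separated than the earlier compounds suggested; the step from the 3-cyanophenyl group to the 4-bromophenyl group lies beyond the scatter (a 5.3-fold lower number from compound 2 to compound 4 (0.73 log units; beyond the scatter)). Nothing measured here bears on the cause of these steps.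

The compounds shown leave open whether chloro, an amine or a carboxylic acid on this aromatic carbon would give a number in the same range. They also leave open whether moving bromo around the ring would matter as moving the nitrile did.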